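Benzyl oxime ether series: a single-atom para swap

The source may report more compounds than this note shows. Statements on the series, on what has been measured and on what is new or still open speak of the compounds shown alone.

Measured so far in a functional assay on A549 cells (Homo sapiens) for cytotoxicity, read by MTT assay, with a stated time of 2 days; on this read-out higher numbers stand for weaker inhibition and lower numbers for stronger inhibition:
compound 1 `c1ccc(CO/N=C2/C(c3c[nH]c4ccccc34)=Nc3ccccc32)cc1` gives 19300 nM;
compound 2 `Cc1ccc(CO/N=C2/C(c3c[nH]c4ccccc34)=Nc3ccccc32)cc1` gives 22400 nM;
compound 3 `Cc1ccc(CO/N=C2/C(c3c[nH]c4ccc(F)cc34)=Nc3ccc(F)cc32)cc1` gives 13600 nM.

Compound 2 holds the highest of the three numbers in this assay, but none of the three stands apart. Its nearest neighbour is compound 1: a 1.2-fold higher number from compound 1 to compound 2 (0.06 log units; within the scatter), within the scatter, so the two cannot be ordered. Within the data shown here, compound 3 lies furthest from compound 2, yet the two values again differ by an amount within the scatter, and compound 3 differs from compound 2 in more than one place, so no single step can be drawn between them.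

Compound 4 `Fc1ccc(CO/N=C2/C(c3c[nH]c4ccccc34)=Nc3ccccc32)cc1` is still to be measured in this assay. It differs from compound 2 by fluoro in place of methyl on an aromatic carbon, that is, 4-methylbenzyl to 4-fluorobenzyl. Among the measured compounds shown here, the only measured step touching this carbon is the one from hydrogen to methyl, a 1.2-fold higher number from compound 1 to compound 2 (0.06 log units; within the scatter), which was within the scatter. For the measured compounds named here, no measured step shows fluoro at this carbon on its own. On that basis no step beyond the scatter is expected for compound 4: the step from compound 2 expected is a 1.2-fold lower number from compound 2 to compound 4 (0.07 log units; within the scatter). Compound 4 is therefore estimated at 19000 nM, with a range of 9000 nM to 40000 nM.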

Compound 4, half-maximal inhibitory concentration: 27000 nM
The estimate for compound 4 lay 1.4-fold (0.15 log units) below the measured number; the range from low to high includes it.
By their numbers in this assay, from the lowest: compounds 3, 1, 2 and 4 (each within the scatter of the next).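

In this assay, the aromatic carbon para to a large group now carries hydrogen, methyl or fluoro, and the new steps are a 1.2-fold higher number from compound 2 to compound 4 (0.08 log units; within the scatter) and a 1.4-fold higher number from compound 1 to compound 4 (0.15 log units; within the scatter), both within the scatter. Among these compounds, compounds 1, 2 and 4 therefore cannot be ordered, and the earlier reading for methyl now extends to a second replacement for hydrogen: fluoro at this carbon, seen on its own for the first time, gives no step beyond the scatter, whether it is read against methyl or against hydrogen. No measurement bears on why this position tolerates these swaps with so little effect on the number, so the flat result stands as an observation only.

From the compounds shown here alone, it remains open whether a group of another kind at this carbon, such as an amine, a carboxylic acid or a longer chain, would give a step beyond the scatter, since the three groups in hand span only a narrow range of substituents. Among the compounds shown here, the fluoro groups on the core of compound 3 also remain unresolved, as compound 3 differs from each of the other compounds in more than one place and no single step isolates them.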